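Dropping a Methoxy Group from a Slowly Cleared Compound

A few compounds are considered here, and "the series" means these few. Any claim that something is new, unique, unknown or untested is made for them only; others in the source may bear on it.

Compound 1 `COc1ccc2c(=O)c(C)c(-c3cncc(-c4ccc(OC(F)(F)F)cc4)c3)[nH]c2c1` holds the lowest of the two numbers recorded in an ADME assay on cells (Hepatocyte, Rattus norvegicus) for metabolic stability, read by LC-MS, using NADPH, with a stated time of 45 min, tested at 3 uM; a lower number here means slower removal, a higher number faster removal of the compound: compound 1 gives 1.2 uL/min. Compound 2 `Cc1c(-c2cncc(-c3ccc(Cl)c(Cl)c3)c2)[nH]c2ccccc2c1=O` gives 9.9 uL/min in this assay, and it differs from compound 1 in more than one place, so these two values are shown only side by side. Compound 3 `Cc1c(-c2cncc(-c3ccc(OC(F)(F)F)cc3)c2)[nH]c2ccccc2c1=O` is compound 1 with hydrogen in place of methoxy on an aromatic carbon. Compound 2 also carries hydrogen at that spot and shows the higher number, so a moderate rise beyond the scatter is expected here. The expected step is a 3.3-fold higher number from compound 1 to compound 3 (0.52 log units; beyond the scatter). For compound 3 the estimate is 4 uL/min, with a range from 1.5 uL/min to 10 uL/min.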

Compound 3, intrinsic clearance in a liver preparation (reported as CLH), per the amount of preparation that the assay uses in the Hepatocyte assay: 1.8 uL/min
Beside the measured number, compound 3's estimate is 2.2-fold (0.35 log units) above it; the range from low to high includes it.
By their numbers in the Hepatocyte assay, from the lowest: compounds 1 and 3 (each within the scatter of the next); then compound 2.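

With hydrogen in place of methoxy on this aromatic carbon, the Hepatocyte assay gives a 1.5-fold higher number from compound 1 to compound 3 (0.18 log units; within the scatter), so the two groups cannot be told apart there. In a physicochemical assay for solubility, measured as kinetic solubility, at pH 7.4, tested at 200 uM (a higher number here means a more soluble compound, a lower number a less soluble compound), compound 1 gives < 1000 nM, which is a limit of the assay and not a number. In the physicochemical assay compound 3 gives 3600 nM, and the step there is an at least 3.6-fold higher number from compound 1 to compound 3 (0.55 log units; beyond the scatter).

Going by these compounds, the full size of that step stays open because one end of it is not a number: the limit of < 1000 nM in the physicochemical assay, at which 1 of the 2 values shown sits. On these data alone, how an amine or a carboxylic acid on this aromatic carbon would read also stays open.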